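This account rests on a few compounds, and the source may have more. Where it says the series, first, only, none or still open, it means among the compounds named here.

The study covers two measured compounds and one awaiting measurement in a functional assay on HCT-15 cells (Homo sapiens) for antiproliferative activity, read by XTT assay; a higher number here means a weaker inhibitor, a lower number a stronger inhibitor. Compound 1 `COc1cccc2occ(Cc3coc4ccccc4c3=O)c(=O)c12` gives 3430 nM in this assay. Compound 2 `Cc1ccc2c(=O)c(Cc3coc4cccc(OCC5CCCCC5)c4c3=O)coc2c1` gives 2220 nM in this assay; the two numbers lie within the usual scatter of each other, so compound 1 sits at one end of the pair without standing apart from compound 2. Compound 3 `O=c1c(Cc2coc3ccccc3c2=O)coc2ccccc12` differs from compound 1 in one place: hydrogen in place of methoxy on an aromatic carbon. Among the compounds with values here, no measured pair shows this change, so the expected step from compound 1 to compound 3 is a 1.2-fold higher number from compound 1 to compound 3 (0.07 log units; within the scatter), modest and not beyond the scatter. Compound 3 is therefore estimated at 4000 nM, with a range from 1500 nM to 11000 nM.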

Compound 3, half-maximal inhibitory concentration: > 10000 nM
Compound 3 ended at the assay's limit; the forecaster's own chance of this, stated with the estimate: 10%; middle value at least 2.5-fold (0.39 log units) away from the limit.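

In this assay hydrogen in place of methoxy on this aromatic carbon gives an at least 2.9-fold higher number from compound 1 to compound 3 (0.46 log units; beyond the scatter) and is the only step shown here that can be read. The methoxy position is therefore not indifferent to this change in the shared core. Compound 3 stands at a limit of the assay, so the step gives only a lower bound: the limit of > 10000 nM in this assay, at which 1 of the 3 values shown sits.

As far as these compounds go, whether an ethoxy, a hydroxyl or a fluorine on this carbon would keep the number of compound 1 stays open. Compound 2 differs from compound 1 in more than one place, so it does not settle this.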